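A few compounds are considered here, and "the series" means these few. Any claim that something is new, unique, unknown or untested is made for them only; others in the source may bear on it.

Compound 1 `COCCO[C@H](CC=C(C)C)C1=CC(=O)c2c(O)ccc(O)c2C1=O` in a functional assay on HeLa cells (Homo sapiens) for cytotoxicity, read by MTT assay (on this read-out higher numbers stand for weaker inhibition and lower numbers for stronger inhibition), gives 62400 nM. Compound 2 `CCC(CO[C@H](CC=C(C)C)C1=CC(=O)c2c(O)ccc(O)c2C1=O)OC(C)=O` gives 44000 nM. Compound 3 `CC(C)=CC[C@@H](OC(=O)C1CCCCO1)C1=CC(=O)c2c(O)ccc(O)c2C1=O` sits at a limit of the assay, > 100000 nM, which is the limit of > 100000 nM in this assay, at which 1 of the 3 values shown sits.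

Compound 1 holds the higher of the two numbers that are not limits, with compound 2 close by, a 1.4-fold lower number from compound 1 to compound 2 (0.15 log units; within the scatter). Compound 4 `CC(C)=CC[C@@H](OC(=O)C1CCCOC1)C1=CC(=O)c2c(O)ccc(O)c2C1=O` differs from compound 1 by (oxan-3-yl)carbonyl in place of 2-methoxyethyl on an oxygen on a saturated carbon. For the measured compounds named here, the step that bears on this is the one to compound 3, an at least 1.6-fold higher number from compound 1 to compound 3 (0.20 log units; that floor lies within the scatter), and also an at least 2.2-fold higher number from compound 2 to compound 3 (0.35 log units; beyond the scatter). A higher number is therefore expected for compound 4, a 1.6-fold higher number from compound 1 to compound 4 (0.20 log units; within the scatter), with a fair chance that only a limit is reported. Compound 4 is estimated at 100000 nM, within a range from 50000 nM to 250000 nM.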

Compound 4, half-maximal inhibitory concentration: 60500 nM
For compound 4 the middle estimate is 1.7-fold (0.22 log units) above the measured one, and the stated range covers the measured number.
By their numbers in this assay, from the lowest: compounds 2, 4 and 1 (each within the scatter of the next). At a limit, above all of these: compound 3.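

In this assay, an ester bearing a ring on this oxygen can sit level with the ethers: (oxan-3-yl)carbonyl for 2-methoxyethyl gives a 1.0-fold lower number from compound 1 to compound 4 (0.01 log units; within the scatter), and for 2-acetoxybutyl gives a 1.4-fold higher number from compound 2 to compound 4 (0.14 log units; within the scatter). The ring attachment point is now tested directly, with oxan-3-yl for oxan-2-yl giving an at least 1.6-fold lower number from compound 3 to compound 4 (0.21 log units; that floor lies within the scatter), so the two attachments are not shown to differ. Compound 3 gives a limit, not a number: the limit of > 100000 nM in this assay, at which 1 of the 4 values shown sits.

Left open is how far compound 3 truly lies from compound 4. Also open, from the compounds shown here alone, is how an oxan-4-yl carbonyl, an amine-bearing piperidine carbonyl or a longer acyl chain would read on this oxygen.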